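Difluoromethyl to Trifluoromethyl, Measured on Two Cores

The source may hold more compounds than are shown below. What is called first, only, known or untested is meant among the compounds shown, and "the series" means these compounds.

Measured compounds:
compound 1 `Fc1cc2nc(-c3cncnc3C(F)F)n(C3CC3)c2cc1F` gives 106%
compound 2 `Fc1cc2nc(-c3cncnc3C(F)(F)F)n(C3CC3)c2cc1F` gives 99%
compound 3 `N#Cc1ccc2nc(-c3cncnc3C(F)F)n(C3CC3)c2c1` gives 84%

Of the compounds shown here, three have been tested in an ADME assay on microsomes from liver (Macaca fascicularis) for metabolic stability, read by LC-MS, with a stated time of 65 min, tested at 1 uM; on this read-out higher numbers stand for a more stable compound and lower numbers for a less stable compound. Compound 1 and compound 2 share one core; compound 3 carries another core, and the difference between the two cores is not broken down here. Compound 3 shows the lowest number of the three, and its values against compound 2 and compound 1 lie beyond the scatter.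

Compound 4 `N#Cc1ccc2nc(-c3cncnc3C(F)(F)F)n(C3CC3)c2c1` is not yet measured. It differs from compound 3 by fluoro in place of hydrogen on a saturated chain carbon bound to an aromatic carbon and two fluorine atoms, and compound 2 differs from compound 1 by fluoro in place of hydrogen on a saturated chain carbon bound to an aromatic carbon and two fluorine atoms; the place is worded the same in both cases, so this is the same change on two cores. On the first core that change gave a number 7 percentage points lower from compound 1 to compound 2 (within the scatter).

Compound 4 is expected to sit close to compound 3 in this assay, with a step of a number 5 percentage points lower from compound 3 to compound 4 (within the scatter), because the only measured case of this change, a number 7 percentage points lower from compound 1 to compound 2 (within the scatter), stayed within the scatter. Compound 4 is therefore estimated at 79%, most likely between 64% and 94%.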

Compound 4, percent of the compound remaining: 62%
Compound 4: middle estimate off by 17 percentage points, on the high side; measured number outside the range, below it.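

On the core of compound 3, the change from difluoromethyl to trifluoromethyl gave a number 22 percentage points lower from compound 3 to compound 4 (beyond the scatter) in this assay. Set beside the result on the first core, this shows that the size of the step did not carry over from one core to the other: the same change on two cores in this assay, a number 7 percentage points lower (within the scatter) from compound 1 to compound 2 and a number 22 percentage points lower (beyond the scatter) from compound 3 to compound 4, 15 percentage points apart, beyond the scatter of two such steps

The comparison rests on a single pair for each core, so it does not show which part of the cores accounts for the gap, nor what size the step would take on any further core. The compounds shown leave open whether the nitrile alone separates the two results, or whether the two fluoro groups of the first core also play a part. Also open, from the compounds shown here alone, is how an amine or a longer fluorinated chain in place of the trifluoromethyl would read on either core in this assay.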